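Chlorine for methoxy on a chalcone arm

This account rests on a few compounds, and the source may have more. Where it says the series, first, only, none or still open, it means among the compounds named here.

Of the compounds shown here, three with a shared dimethyl-dihydrobenzofuran chalcone core have been tested in a functional assay on PC-3 cells (Homo sapiens) for antiproliferative activity, read by MTT assay, with a stated time of 48 h; a lower number here means a stronger inhibitor, a higher number a weaker inhibitor. Compound 1, `CC1(C)Cc2c(O)ccc(C(=O)/C=C/c3cn(-c4ccccc4)nc3-c3ccc(Cl)cc3)c2O1`, gives 18000 nM in this assay. Compound 2, `COc1ccc(-c2nn(-c3ccccc3)cc2/C=C/C(=O)c2ccc(O)c3c2OC(C)(C)C3)cc1`, gives 20800 nM in this assay. Compound 3, `COc1ccc(/C=C/C(=O)c2ccc(OCc3ccccc3)c3c2OC(C)(C)C3)cc1`, gives 13500 nM in this assay. All three numbers sit close together, and none of the gaps between them is larger than the usual scatter of such measurements, so no order among the three can be read from them.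

Compounds 1 and 2 differ in a single place: chloro in place of methoxy on an aromatic carbon The step of a 1.2-fold lower number from compound 2 to compound 1 (0.06 log units; within the scatter) is small and lies within the scatter. How the core of compound 3 differs from the core of compound 2 is not broken down here.

The unmeasured compound 4, `CC1(C)Cc2c(OCc3ccccc3)ccc(C(=O)/C=C/c3ccc(Cl)cc3)c2O1`, stands to compound 3 as compound 1 stands to compound 2: chloro in place of methoxy on an aromatic carbon The place of the change reads the same for both pairs, so it is the same change, made a second time on a different core. Within the data shown here, the only guide to its size is the step from compound 2 to compound 1, which was within the scatter. On that basis the step from compound 3 to compound 4 is expected to be about a 1.1-fold lower number from compound 3 to compound 4 (0.05 log units; within the scatter), again within the scatter, and compound 4 is estimated at 12000 nM in this assay, with a range from 6000 nM to 25000 nM.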

Compound 4, half-maximal inhibitory concentration: > 100000 nM
Compound 4 gave a limit, no number; the forecaster's own chance of this, stated with the estimate: 10%; at least 8.3-fold (0.92 log units) between middle value and limit.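

In this assay compound 4 gives > 100000 nM, which is a limit of the assay and not a number. Even so, chloro in place of methoxy clearly does not carry over from one core to the other as a step of fixed size, for an at least 7.4-fold higher number from compound 3 to compound 4 (0.86 log units; beyond the scatter) is set against a step within the scatter on the first pair: the same change on two cores in this assay, a 1.2-fold lower number (0.06 log units; within the scatter) from compound 2 to compound 1 and an at least 7.4-fold higher number (0.86 log units; beyond the scatter) from compound 3 to compound 4, at least 8.5-fold (0.93 log units) apart, beyond the scatter of two such steps The result does not show which feature of the two cores sets these steps apart, and it gives only a bound on the step, not its full size: the limit of > 100000 nM in this assay, at which 1 of the 4 values shown sits.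

With one pair on each core, the compounds shown leave open whether the large step belongs to the core of compound 3 alone or would recur on other cores that carry a benzyloxy group. They also leave open whether another group at the same aromatic carbon, such as fluoro, methyl or a dimethylamino group, would on the core of compound 3 give a value close to that of compound 3 or one that falls away as with chloro in compound 4.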